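The compounds below may be only part of what the source reports. "The series", "measured", "known", "first", "only" and "open" are said of these compounds alone.

Of the compounds shown here, three sharing one core have been measured in a functional assay on cells (T-cell, Mus musculus, strain BALB/c) for inhibition, read by MTT assay, with stated times of 24 h and 72 h; on this read-out higher numbers stand for weaker inhibition and lower numbers for stronger inhibition. Compound 1 `COc1cc(-c2nnc(SCc3ccc(F)cc3F)o2)ccc1O` gives 9690 nM, compound 2 `COc1cc(-c2nnc(SCc3ccccc3C)o2)ccc1O` gives 8420 nM, and compound 3 `COc1cc(-c2nnc(SCc3ccc(Br)cc3)o2)ccc1O` gives 8830 nM. Compound 2 has the lowest of the three numbers, yet the steps of a 1.2-fold lower number from compound 1 to compound 2 (0.06 log units; within the scatter) and a 1.0-fold higher number from compound 2 to compound 3 (0.02 log units; within the scatter) lie within the scatter, as does a 1.1-fold lower number from compound 1 to compound 3 (0.04 log units; within the scatter). Compound 4 `COc1cc(-c2nnc(SCc3ccccc3C)o2)ccc1OCc1ccccc1C` differs from compound 2 by 2-methylbenzyl in place of hydrogen on an oxygen on an aromatic ring. Among the measured compounds shown here, no measured step touches this oxygen; all three vary the group on the saturated chain carbon bound to a sulfur, and none of them moved the number beyond the scatter. For the measured compounds named here, with no precedent at this position, compound 4 is expected to show a 1.1-fold higher number from compound 2 to compound 4 (0.03 log units; within the scatter). The estimate for compound 4 in this assay is 9000 nM, with a range from 2500 nM to 32000 nM.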

Compound 4, half-maximal inhibitory concentration: 18900 nM
Beside the measured number, compound 4's estimate is 2.1-fold (0.32 log units) below it; low and high end bracket the measured number.
By their numbers in this assay, from the lowest: compounds 2, 3, 1 and 4 (each within the scatter of the next, the first and the last beyond it).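

In this assay, going from hydroxy to (2-methylbenzyl)oxy gives a 2.2-fold higher number from compound 2 to compound 4 (0.35 log units; beyond the scatter) and is the only step shown that lies beyond the scatter. This oxygen on an aromatic ring therefore affects the number, whereas the changes on the saturated chain carbon bound to a sulfur did not, and the effect here is a modest weakening. Nothing available accounts for this shift.

As far as these compounds go, it remains open whether any group on this oxygen weakens inhibition or only 2-methylbenzyl does. A plain methyl or unsubstituted benzyl would help separate those possibilities, and a chain ending in an amine would test a different kind of group.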